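The compounds below may be only part of what the source reports. "The series", "measured", "known", "first", "only" and "open" are said of these compounds alone.

Measured in a functional assay on A-375 cells (Homo sapiens) for inhibition, read by CCK-8 assay, with a stated time of 72 h, tested at 8 uM; on this read-out higher numbers stand for more inhibition of growth at the one concentration tested and lower numbers for less inhibition of growth:
- compound 1 `CCc1ccc(SCc2ccc(/C=C/C(=O)Nc3ccccc3N)cc2)cc1`: 58.4%
- compound 2 `COc1ccc(SCc2ccc(C(=O)Nc3ccccc3N)cc2)cc1`: 81.8%
- compound 3 `Nc1ccccc1NC(=O)c1ccc(CSc2cccc(F)c2)cc1`: 76.3%

Compound 1, at 58.4%, is the lowest of the three numbers in this assay. Compound 3 and compound 2 both stand higher than it by more than the scatter, while the two of them do not separate from each other.

Next in the series is compound 4 `Nc1ccccc1NC(=O)/C=C/c1ccc(CSc2cccc3ccccc23)cc1`, which keeps the rest of compound 1 and changes one group: naphthalen-1-yl in place of 4-ethylphenyl on a sulfur. In words, naphthalen-1-yl stands in place of 4-ethylphenyl on a sulfur.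

Within the data shown here, only one measured step bears on this place, a swap of one aryl group on the sulfur for another: a number 5.5 percentage points lower from compound 2 to compound 3 (within the scatter). That step is small, but it is a single pair and it was not measured on the core of compound 1. Among the measured compounds shown here, no measured compound carries naphthalen-1-yl, so the guide is weak and the range has to stay wide. On that one step, no shift beyond the scatter is expected in this assay, in either direction.

The estimate therefore means a number 1.6 percentage points higher from compound 1 to compound 4 (within the scatter), an expected step that stays within the scatter. For compound 4 the estimated value is 60%, with an expected range of 45% to 76%.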

Compound 4, percent growth inhibition at one concentration: 36%
Compound 4: middle estimate off by 24 percentage points, on the high side; the whole stated range lies above it.
By their numbers in this assay, from the lowest: compound 4; then compound 1; then compounds 3 and 2 (each within the scatter of the next).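

In this assay, among these compounds, the group on the sulfur is not a neutral place on the core of compound 1: naphthalen-1-yl in place of 4-ethylphenyl gives a number 22.4 percentage points lower from compound 1 to compound 4 (beyond the scatter), and this is the first swap at this place to pass the scatter. Among the compounds shown here, the only earlier swap here, a number 5.5 percentage points lower from compound 2 to compound 3 (within the scatter), joined two single-ring aryl groups on a different core, whereas the entering group in this step brings a second six-membered aromatic ring and also removes the ethyl chain, so this one pair cannot separate those two parts of the change. Nothing at hand accounts for the lower number in this step.

Open, going by these compounds, is whether naphthalen-1-yl on the core of compound 2 would follow the same direction, or whether this step belongs to the core of compound 1 alone. Also open, on these data alone, is how naphthalen-2-yl, a plain phenyl or a phenyl carrying an amine or a carboxylic acid would stand on the sulfur, which would show whether the second ring or its point of attachment goes with the lower number.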